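The compounds below may be only part of what the source reports. "The series", "measured", "known", "first", "only" and "open" are said of these compounds alone.

Measured compounds:
Compound 1, `COc1ccc2cccc(C3CNC(=O)C3)c2c1` — 1580 nM
Compound 2, `COc1ccc2cccc(CCCC(N)=O)c2c1` — 20 nM

Among the measured compounds shown here, in an assay (Ovis aries) for binding affinity to melatonin receptor type 1A (Homo sapiens) (on this read-out lower numbers stand for stronger inhibition and higher numbers for weaker inhibition), compound 2 gives the lowest of the two numbers; its nearest neighbour is compound 1, and the only measured step, a 79-fold lower number from compound 1 to compound 2 (1.90 log units; beyond the scatter), is a large one and separates the two clearly. Compound 3, `COc1ccc2cccc(CONC(C)=O)c2c1`, has not been measured yet. It differs from compound 2 in one place: a group of 5 heavy atoms (2 carbon, 1 nitrogen, 2 oxygen; no ring) in place of a group of 5 heavy atoms (3 carbon, 1 nitrogen, 1 oxygen; no ring), on a saturated chain carbon bound to an aromatic carbon. The chain keeps its length and its amide, but the terminus is changed. The measured step from compound 1 to compound 2 concerns a ring opened into a chain on the shared core, not a change within the chain itself, so it bears only loosely on this step. It does show that this assay answers strongly to the shape of the side chain, so a change within the chain is expected to cost something rather than nothing. The expected step is a 7.5-fold higher number from compound 2 to compound 3 (0.88 log units; beyond the scatter). For compound 3 the estimate in this assay is 150 nM, with a range from 20 nM to 1500 nM.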

Compound 3, half-maximal inhibitory concentration: 7.94 nM
Estimate against measurement, compound 3: 19-fold (1.28 log units) above; the whole stated range lies above it.
By their numbers in this assay, from the lowest: compound 3; then compound 2; then compound 1.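

In this assay, the end of the side chain proves open to change at this place: a 2.5-fold lower number from compound 2 to compound 3 (0.40 log units; beyond the scatter) is a modest step that lies beyond the scatter, and it goes towards a lower number, so rewriting the end does not cost binding here. The group that replaces 2-carbamoylethyl has the same count of 5 heavy atoms, with an oxygen in place of a carbon and 2 hydrogen-bond acceptors instead of 1, so this swap is tolerated and even slightly favoured. The open chain also keeps its large lead over the ring of compound 1 with this new end, as a 200-fold lower number from compound 1 to compound 3 (2.30 log units; beyond the scatter) shows, although nothing available explains why the new group does better.

Compound 3 alters the chain and its amide together, so the compounds shown cannot tell which part of the change carries the step. From the compounds shown here alone, how a longer chain, or an amine or a carboxylic acid in place of the amide, would fare in this assay also remains open.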